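Ester variants on a shared core: cytotoxicity working notes

The source may report more compounds than this note shows. Statements on the series, on what has been measured and on what is new or still open speak of the compounds shown alone.

Measured so far:
compound 1, `C=C1C(=O)O[C@@H]2CC(C)=C([C@@H](C)CCCOC(C)=O)[C@@H](OC(=O)CCl)[C@H]12` — in a functional assay on HeLa cells (Homo sapiens) for cytotoxicity, read by sulforhodamine B assay, with a stated time of 72 h (a lower number here means a stronger inhibitor, a higher number a weaker inhibitor), compound 1 gives 28500 nM
compound 2, `C=C1C(=O)O[C@@H]2CC(C)=C([C@@H](C)CCCOC(C)=O)[C@@H](OC(=O)COc3ccc(C(=O)OCCC)cc3)[C@H]12` — in this assay compound 2 gives 22900 nM
compound 3, `C=C1C(=O)O[C@@H]2CC(C)=C([C@@H](C)CCCOC(C)=O)[C@@H](OC(=O)COc3ccc([N+](=O)[O-])cc3[N+](=O)[O-])[C@H]12` — in this assay compound 3 gives > 100000 nM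

Compound 1 and compound 2 sit within the usual scatter of each other, so no order between them is claimed. Compound 3 gives only a limit in this assay, namely (the limit of > 100000 nM in this assay, at which 1 of the 3 values shown sits), and no number is known for it. For the measured compounds named here, the single measured step is an at least 4.3-fold higher number from compound 2 to compound 3 (0.64 log units; beyond the scatter), an at least modest rise that ends at the limit.

Compound 4, `C=C1C(=O)O[C@@H]2CC(C)=C([C@@H](C)CCCOC(C)=O)[C@@H](OC(=O)COc3cccc4cccnc34)[C@H]12`, is not yet measured. It differs from compound 3 by quinolin-8-yl in place of 2,4-dinitrophenyl on an oxygen on a saturated carbon. Going by the values given here, the only step that bears on this change is an at least 4.3-fold higher number from compound 2 to compound 3 (0.64 log units; beyond the scatter), in which exchanging one aryl group for the 2,4-dinitrophenyl pushed the number up to the limit. Since the change to compound 4 removes that same 2,4-dinitrophenyl in favour of another aryl group, a move back in the downward direction, toward the numbers of compound 1 and compound 2, is expected, though its size is uncertain. Compound 4 is therefore estimated at 35000 nM, with a range of 10000 nM to 120000 nM. The expected step is an at least 2.8-fold lower number from compound 3 to compound 4 (0.45 log units; beyond the scatter).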

Compound 4, half-maximal inhibitory concentration: 8940 nM
The estimate for compound 4 lay 3.9-fold (0.59 log units) above the measured number, and the stated range ends above it.
By their numbers in this assay, from the lowest: compound 4; then compounds 2 and 1 (each within the scatter of the next). At a limit, above all of these: compound 3.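

On an oxygen on a saturated carbon, an aryl group now takes the number clearly below that of the chloro compound and of another aryl compound in this assay: the change to quinolin-8-yl gives a 2.6-fold lower number from compound 2 to compound 4 (0.41 log units; beyond the scatter) and, from the chloroacetate, a 3.2-fold lower number from compound 1 to compound 4 (0.50 log units; beyond the scatter), so compound 4 has the lowest number of the four. The same aryl exchange away from 2,4-dinitrophenyl gives an at least 11-fold lower number from compound 3 to compound 4 (1.04 log units; beyond the scatter), which makes this the largest step in the series, yet aryl groups as a class do not lower the number, since compound 2, with 4-(propoxycarbonyl)phenyl, and compound 3 both go against such a pattern. Compound 3 gives a limit and not a number, so the true size of its step stays unknown: the limit of > 100000 nM in this assay, at which 1 of the 4 values shown sits.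

Still open, going by these compounds, is whether the gain belongs to the aromatic ring with the hetero atom in quinolin-8-yl or to the two fused rings as such, which a naphthalen-1-yl group on the same oxygen would separate. Also open, on these data alone, is how a plain phenyl group, or a phenyl group carrying an amine or a carboxylic acid, would read in this position.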